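Sulfonamide nitrogen aryl swap: pyridine to pyrazole

A few compounds are considered here, and "the series" means these few. Any claim that something is new, unique, unknown or untested is made for them only; others in the source may bear on it.

Compound 2 `Cc1ccc(S(=O)(=O)N(CC(=O)NCc2ccc(Cl)cc2)c2ccc(C)cn2)cc1` shares its core with compound 1 `Cc1ccc(S(=O)(=O)N(CC(=O)NCc2ccc(Cl)cc2)c2cccc(C)n2)cc1`. In a functional assay on CHO-K1 cells for antagonist activity at prostaglandin E2 receptor EP1 subtype (Homo sapiens), read by FLIPR and calcium flux (a higher number here means a weaker inhibitor, a lower number a stronger inhibitor), compound 2 gives < 1450 nM, which is a limit of the assay rather than a number. In this assay compound 1 gives < 1450 nM, likewise a limit. The step that the two limits leave unreadable from compound 1 to compound 2 therefore cannot be sized, since both values sit at the limit of < 1450 nM in this assay, at which 2 of the 2 values shown sit. Compound 3 `CCn1nccc1N(CC(=O)NCc1ccc(Cl)cc1)S(=O)(=O)c1ccc(C)cc1` differs from compound 2 by 1-ethyl-1H-pyrazol-5-yl in place of 5-methylpyridin-2-yl on a sulfonamide nitrogen. Going by the values given here, no measured step bears on this change: the only step is unreadable, and nothing else alters the aryl group on the sulfonamide nitrogen in a way that can be read. The expectation for compound 3 thus rests on the limit of compound 2 alone, so no step beyond the scatter is assumed, and the expected step is a step that the limit leaves unreadable from compound 2 to compound 3. Compound 3 is estimated at 700 nM in this assay, with a range from 100 nM to 4000 nM, and a further limit rather than a number is quite possible.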

Compound 3, inhibition constant: 72.4 nM
Compound 3: the middle estimate sits 9.7-fold (0.99 log units) above what was measured, and the stated range ends above it.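

The steps from compound 1 and from compound 2 to compound 3 cannot be read in this assay, because compound 1 and compound 2 each carry only a limit: the limit of < 1450 nM in this assay, at which 2 of the 3 values shown sit.

The compounds shown leave open how large the change to 1-ethyl-1H-pyrazol-5-yl is, and whether 5-methylpyridin-2-yl and 6-methylpyridin-2-yl differ at all.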